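Chloro in place of bromo: expecting little change

The source may report more compounds than this note shows. Statements on the series, on what has been measured and on what is new or still open speak of the compounds shown alone.

Compound 1 `Cn1c([N+](=O)[O-])cnc1/C=C/c1ccccc1` reads > 100000 nM in an ADME assay on HeLa cells (Homo sapiens) for cytotoxicity, read by resazurin assay, with a stated time of 2 days (on this read-out higher numbers stand for weaker inhibition and lower numbers for stronger inhibition), which is a limit of the assay and not a number. Compound 2 `Cc1ccccc1/C=C/c1ncc([N+](=O)[O-])n1C` gives 93300 nM. Compound 3 `Cn1c([N+](=O)[O-])cnc1/C=C/c1ccccc1Br` gives 72400 nM, so the two exact numbers cannot be told apart: a 1.3-fold lower number from compound 2 to compound 3 (0.11 log units; within the scatter).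

Compound 4 `Cn1c([N+](=O)[O-])cnc1/C=C/c1ccccc1Cl` differs from compound 3 by one swap (chloro in place of bromo on an aromatic carbon), chloro in place of bromo on an aromatic carbon. The measured steps that bear on it are all small. Adding bromo gave an at least 1.3-fold lower number from compound 1 to compound 3 (0.14 log units; that floor lies within the scatter), and adding methyl gave an at least 1.0-fold lower number from compound 1 to compound 2 (0.03 log units; that floor lies within the scatter). No step beyond the scatter is therefore expected in this assay. The estimated step is a 1.1-fold higher number from compound 3 to compound 4 (0.03 log units; within the scatter). Compound 4 is expected near 78000 nM, within an estimated range of 45000 nM to 100000 nM.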

Compound 4, half-maximal inhibitory concentration: > 100000 nM
Compound 4 was reported as a limit; the forecaster's own chance of this, stated with the estimate: 15%; middle value at least 1.2-fold (0.10 log units) from the limit.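

In this assay, chloro in place of bromo gives an at least 1.3-fold higher number from compound 3 to compound 4 (0.14 log units; that floor lies within the scatter), and chloro in place of methyl gives an at least 1.0-fold higher number from compound 2 to compound 4 (0.03 log units; that floor lies within the scatter). So among hydrogen, methyl, bromo and chloro on this aromatic carbon, no readable step goes beyond the scatter. The value of compound 4 is a limit and not a number, and the step between compound 1 and compound 4 cannot be read: the limit of > 100000 nM in this assay, at which 2 of the 4 values shown sit.

On these data alone, whether an amine or a carboxylic acid on this carbon would give a step beyond the scatter remains open. So does the true size of the steps to compound 4, since only their floors can be read.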